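Swapping a methylsulfonyl for chloro on a weak agonist

The source may report more compounds than this note shows. Statements on the series, on what has been measured and on what is new or still open speak of the compounds shown alone.

Of the compounds shown here, two have been measured so far. Compound 1 `Cn1ccnc1[C@@H](CC(=O)O)c1ccc(OCc2cccc(-c3ccccc3S(C)(=O)=O)c2)cc1` and compound 2 `Cc1cc(Cl)ccc1-c1cc(COc2ccc([C@H](CC(=O)O)c3nccn3C)cc2)ccc1C` share an acid-bearing core joined through a linker to a biaryl group. In an assay on CHO cells for agonist activity at Free fatty acid receptor 1 (Homo sapiens), read by luminescence, with a stated time of 20 s, in the presence of a further agent that is not named here (on this read-out higher numbers stand for an effect only at larger amounts of compound and lower numbers for an effect already at smaller amounts), compound 1 gives 23000 nM, while compound 2 gives 97 nM. Of the two numbers, compound 1 has the higher one, and its gap to compound 2 lies beyond the usual scatter, so compound 1 is the weaker of the pair.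

Compound 3 `Cn1ccnc1[C@@H](CC(=O)O)c1ccc(OCc2cccc(-c3ccccc3Cl)c2)cc1` has not yet been measured. It differs from compound 1 in one place: chloro in place of methylsulfonyl on an aromatic carbon. Within the data shown here, no measured pair shows exactly this change, so the step can only be judged from the two compounds at hand. Since compound 2, which also carries a chloro on its outer ring, gives 97 nM, a move toward lower numbers is expected. For compound 3 the estimated step of a 9.2-fold lower number from compound 1 to compound 3 (0.96 log units; beyond the scatter) would place its value in this assay at about 2500 nM, within a range from 400 nM to 12000 nM.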

Compound 3, half-maximal effective concentration: 43 nM
Compound 3: middle estimate off by 58-fold (1.76 log units), on the high side; the whole stated range lies above it.
By their numbers in this assay, from the lowest: compound 3; then compound 2; then compound 1.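

In this assay, going from 2-(methylsulfonyl)phenyl to 2-chlorophenyl gives a 530-fold lower number from compound 1 to compound 3 (2.73 log units; beyond the scatter), so a change at this one aromatic carbon, ortho to a large group, is enough to move the read-out by a very large step. The first two compounds differ in more than one place, so they could not tie any of their gap to a single group, whereas this pair does. The methylsulfonyl group carries hydrogen-bond acceptors and the chloro carries none, but nothing available shows whether that difference, or any other, accounts for the step.

On these data alone, it remains open how a fluoro, a methyl, a methoxy or an amine would fare at this same place. As far as these compounds go, it is also open whether the swap from methylsulfonyl to chloro would give a step of similar size on a different core.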